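Swapping a Pyrimidine for a Triazole on a Sulfonyl Hydrazide

The compounds below may be only part of what the source reports. "The series", "measured", "known", "first", "only" and "open" are said of these compounds alone.

Compound 2 `Cc1cc(-c2ncccn2)cc(C(=O)NNS(=O)(=O)c2ccccc2)c1F` gives 279 uL/min in an ADME assay on microsomes from liver (Mus musculus) for metabolic stability, read by HPLC, using NADPH, with a stated time of 60 min, tested at 1 uM, in the presence of a further agent that is not named here (on this read-out lower numbers stand for slow clearance and higher numbers for fast clearance), the second highest of three numbers: compound 1 `O=C(NNS(=O)(=O)c1ccccc1F)c1cc(F)cc(-c2ccccn2)c1` gives 131 uL/min and compound 3 `C=CCOc1cc(F)cc(C(=O)NNS(=O)(=O)c2ccccc2F)c1` gives 803 uL/min. For the measured compounds named here, the only measured single-point step runs a 6.1-fold higher number from compound 1 to compound 3 (0.79 log units; beyond the scatter); it shows that the group on this aromatic carbon can shift clearance well beyond the scatter, but it exchanges pyridin-2-yl for allyloxy rather than one heteroaromatic ring for another. Compound 4 `Cc1cc(-n2nccn2)cc(C(=O)NNS(=O)(=O)c2ccccc2)c1F` differs from compound 2 by 2H-1,2,3-triazol-2-yl in place of pyrimidin-2-yl on an aromatic carbon. Going by the values given here, no measured step of this kind exists, so only a small change is expected, in either direction. Compound 4 is therefore estimated at 250 uL/min, within 120 uL/min to 520 uL/min. The expected step is a 1.1-fold lower number from compound 2 to compound 4 (0.05 log units; within the scatter), likely staying near the scatter.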

Compound 4, intrinsic clearance in a liver preparation (reported as CLH), per the amount of preparation that the assay uses in the Mus musculus assay: 865 uL/min
The estimate for compound 4 lay 3.5-fold (0.54 log units) below the measured number; measured number outside the range, above it.
By their numbers in the Mus musculus assay, from the lowest: compound 1; then compound 2; then compounds 3 and 4 (each within the scatter of the next).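

In the Mus musculus assay the step is a 3.1-fold higher number from compound 2 to compound 4 (0.49 log units; beyond the scatter), so exchanging pyrimidin-2-yl for 2H-1,2,3-triazol-2-yl shows that a change from one aromatic ring to another at this carbon can move clearance beyond the scatter. In a physicochemical assay for solubility, read by nephelometry, measured as kinetic solubility, at pH 2 (on this read-out lower numbers stand for lower solubility and higher numbers for higher solubility), compound 2 gives 50 ug/mL and compound 4 gives 25 ug/mL, two values within the scatter of each other. Nothing available here accounts for the clearance step.

As far as these compounds go, whether a small amine or a carboxylic acid on this carbon would give lower clearance remains open. So does whether the same ring exchange carries over to the core of compound 1.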